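Fluoro to methoxymethoxy on the compound 1 scaffold

The source may report more compounds than this note shows. Statements on the series, on what has been measured and on what is new or still open speak of the compounds shown alone.

In a toxicity assay on MDCK cells (Canis lupus familiaris) for cytotoxicity, read by crystal violet staining, with a stated time of 48 h (on this read-out lower numbers stand for higher toxicity in this test and higher numbers for lower toxicity in this test), compound 1 (`CCc1ccc2[nH]c(=O)c(CN(Cc3ccc(F)cc3)Cc3ccc(C(C)(C)C)cc3)cc2c1`) reads > 33000 nM and this is a limit of the assay, not a number. Compound 2 (`CCCc1ccc2[nH]c(=O)c(CN(Cc3ccc(F)cc3)Cc3ccc(C(C)(C)C)cc3)cc2c1`) reads 8400 nM as a measured number. Compound 3 (`CCc1ccc2[nH]c(=O)c(CN(Cc3ccc(OCOC)cc3)Cc3ccc(C(C)(C)C)cc3)cc2c1`) is still unmeasured and differs from compound 1 by methoxymethoxy in place of fluoro on an aromatic carbon with methoxymethoxy in place of fluoro on an aromatic carbon, para to a large group. Among the measured compounds shown here, the only measured step, an at least 3.9-fold lower number from compound 1 to compound 2 (0.59 log units; beyond the scatter), lies on a saturated chain carbon rather than at this place, so it bears on the change only indirectly. For the measured compounds named here, no measured step covers this exchange itself. A modest move toward a lower number is expected, with an at least 1.3-fold lower number from compound 1 to compound 3 (0.12 log units; that floor lies within the scatter) as the estimated step, and a second limit reading would not be surprising. For compound 3 the estimated value is 25000 nM with an expected range from 9000 nM to 60000 nM in this assay once measured.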

Compound 3, half-maximal cytotoxic concentration: > 10000 nM
Compound 3 ended at the assay's limit; the forecaster's own chance of this, stated with the estimate: 50%; the middle value does not contradict the limit.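

In this assay compound 1 reads > 33000 nM, which is a limit of the assay. Compound 3 reads > 10000 nM, also a limit, so the step between compound 1 and compound 3 cannot be read. Going by these compounds, whether methoxymethoxy in place of fluoro on an aromatic carbon changes the read-out at all stays open.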